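Nitro for Bromo on Two Related Cores in Vero Cells

This account rests on a few compounds, and the source may have more. Where it says the series, first, only, none or still open, it means among the compounds named here.

Compound 1 `O=C(NNC(=O)c1ccc([N+](=O)[O-])cc1)c1ccc(-n2cccc2)cc1` and compound 2 `O=C(NNC(=O)c1ccc(-n2cccc2)cc1)c1ccc(Br)cc1` share one core and differ in a single group, while compound 3 `Brc1ccc(-c2nnc(-c3ccc(-n4cccc4)cc3)o2)cc1` and compound 4 `O=[N+]([O-])c1ccc(-c2nnc(-c3ccc(-n4cccc4)cc3)o2)cc1` share another. The difference between the two cores is not broken down here.

In an ADME assay on Vero cells (Chlorocebus sabaeus) for cytotoxicity, read by MTT assay, with a stated time of 72 h (on this read-out lower numbers stand for stronger inhibition and higher numbers for weaker inhibition), compound 2 gives 186000 nM. In this assay compound 1 gives 190000 nM. The change between the two, (nitro in place of bromo on an aromatic carbon), made the step of a 1.0-fold higher number from compound 2 to compound 1 (0.01 log units; within the scatter). In this assay compound 3 gives 260000 nM. Its gaps to compound 1 and to compound 2 are both within the scatter, so no order among these three compounds can be read from the numbers.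

Compound 4 carries the same change on the second core: nitro in place of bromo on an aromatic carbon. Among the compounds considered, this change appears twice, and the surroundings of the place are the same in both cases, so the change from compound 3 to compound 4 is the same change as the one from compound 2 to compound 1. The earlier step left the number essentially where it was. The step now expected is no change at the digits printed from compound 3 to compound 4 (within the scatter), and this expectation rests on the step of a 1.0-fold higher number from compound 2 to compound 1 (0.01 log units; within the scatter) together with the value of compound 3 in this assay, 260000 nM. Compound 4 is accordingly estimated at 260000 nM. The plausible range for compound 4 is expected to run from 130000 nM to 520000 nM.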

Compound 4, half-maximal inhibitory concentration: 258000 nM
Beside the measured number, compound 4's estimate is 1.0-fold (0.00 log units) above it, and the stated range covers the measured number.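

In this assay, the new step reads a 1.0-fold lower number from compound 3 to compound 4 (0.00 log units; within the scatter), so nitro in place of bromo on an aromatic carbon gives no difference beyond the scatter on the second core, just as it gives none on the first. Set side by side, the two steps agree, and in this small set the change carries from one core to the other with the same outcome: the same change on two cores in this assay, a 1.0-fold higher number (0.01 log units; within the scatter) from compound 2 to compound 1 and a 1.0-fold lower number (0.00 log units; within the scatter) from compound 3 to compound 4, 1.0-fold (0.01 log units) apart, within the scatter of two such steps. Among the compounds shown here, this shows only that two steps of negligible size match on these two cores in this one assay; it does not show that a step of real size would carry across in the same way, that the match would hold on any further core, or that it would hold on any other read-out.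

The compounds shown hold only bromo and nitro at this place, on an aromatic carbon para to a large group, so it remains open how an amine, a carboxylic acid or a longer chain there would read in this assay. Also open, going by these compounds, is whether either group would give the same result at another place on that ring, and what separate parts of the two cores contribute to these numbers.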